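Shifting the aryl group on the sulfonamide nitrogen

The compounds below may be only part of what the source reports. "The series", "measured", "known", "first", "only" and "open" are said of these compounds alone.

Three compounds share one core and differ only in the aryl group on the sulfonamide nitrogen. Compound 1 `O=C1NCCN1c1ccc(S(=O)(=O)Nc2ccc(C3CCCCC3)cc2)cc1` carries a cyclohexyl group, compound 2 `CCCCc1ccc(NS(=O)(=O)c2ccc(N3CCNC3=O)cc2)cc1` a butyl group, and compound 3 `O=C1NCCN1c1ccc(S(=O)(=O)Nc2ccc(Cl)cc2)cc1` a chloro group. In a functional assay on MCF7 cells (Homo sapiens) for antiproliferative activity, read by sulforhodamine B assay, with a stated time of 48 h (on this read-out lower numbers stand for stronger inhibition and higher numbers for weaker inhibition), compound 1 gives > 1000 nM; this is the limit of > 1000 nM in this assay, at which 1 of the 3 values shown sits, not a number. In this assay, going by the values given here, compound 2 gives 770 nM and compound 3 gives 170 nM, which is the lowest of the two numbers known. The steps run an at least 1.2-fold lower number from compound 1 to compound 2 (0.11 log units; that floor lies within the scatter), an at least 5.8-fold lower number from compound 1 to compound 3 (0.76 log units; beyond the scatter) and a 4.5-fold lower number from compound 2 to compound 3 (0.66 log units; beyond the scatter).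

Compound 4 `COc1cccc(NS(=O)(=O)c2ccc(N3CCNC3=O)cc2)c1` is not yet measured. It differs from compound 3 in one place: 3-methoxyphenyl in place of 4-chlorophenyl on a sulfonamide nitrogen. Every measured step swaps the group on an aromatic carbon of that same ring, and together they show that the small chloro group gave clearly lower numbers than the larger cyclohexyl or butyl groups. None of them, however, swaps chloro for methoxy or moves the group to another carbon, so they bear only loosely on this change. The new group is of similar size, so no large loss is expected, but a modest rise seems more likely than a fall; the expected step is a 2.4-fold higher number from compound 3 to compound 4 (0.37 log units; beyond the scatter). Compound 4 is therefore estimated at 400 nM in this assay, within 120 nM to 1500 nM.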

Compound 4, half-maximal inhibitory concentration: 120 nM
Compound 4: middle estimate off by 3.3-fold (0.52 log units), on the high side, within the range that was stated.
By their numbers in this assay, from the lowest: compounds 4 and 3 (each within the scatter of the next); then compound 2. At a limit, above all of these: compound 1.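

In this assay, putting 3-methoxyphenyl in place of 4-chlorophenyl on the sulfonamide nitrogen produces no change that stands out from the scatter (a 1.4-fold lower number from compound 3 to compound 4 (0.15 log units; within the scatter)). The earlier steps shown here only exchanged chloro, butyl and cyclohexyl groups on an aromatic carbon, whereas this pair shows that two differently substituted phenyl groups can give numbers that cannot be told apart at this place, so chloro is not required within this small set. Nothing shown here explains why compound 3 and compound 4 give such close numbers.

On these data alone, how 4-methoxyphenyl or 3-chlorophenyl would compare remains open, so the choice of group cannot yet be separated from where it sits on the ring. Also open, as far as these compounds go, is what a phenyl group carrying an amine or a carboxylic acid would give on this nitrogen.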